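Adding a Second Chlorine: Expected Cytotoxicity of Compound 4

The source may hold more compounds than are shown below. What is called first, only, known or untested is meant among the compounds shown, and "the series" means these compounds.

Of the compounds shown here, three that share one core have been tested in an ADME assay on NHDF cells (Homo sapiens) for cytotoxicity, read by MTT assay, with a stated time of 72 h; a higher number here means a weaker inhibitor, a lower number a stronger inhibitor. Compound 1 `COc1cccc(/C=C2\CCC/C(=C\c3ccccc3Cl)C2=O)c1OC` gives 44200 nM. Compound 2 `COc1ccc(/C=C2\CCC/C(=C\c3cccc(OC)c3OC)C2=O)cc1` gives 43500 nM. Compound 3 `COc1ccc(/C=C2\CCC/C(=C\c3cccc(Cl)c3)C2=O)cc1OC` gives 11900 nM, the lowest of the three numbers; its gap to compound 2 and its gap to compound 1 both lie beyond the usual scatter, so compound 3 is the strongest inhibitor among the three.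

Among the measured compounds shown here, only one pair of measured compounds differs in a single place, and that step is a 1.0-fold lower number from compound 1 to compound 2 (0.01 log units; within the scatter).

Compound 4 `COc1ccc(/C=C2\CCC/C(=C\c3ccc(Cl)cc3Cl)C2=O)cc1OC` has not yet been measured in this assay. It differs from compound 3 in one place: 2,4-dichlorophenyl in place of 3-chlorophenyl on a double-bonded chain carbon bound to a double-bonded ring carbon.

For the measured compounds named here, the step from compound 1 to compound 2 is the only measured step that exchanges the ring at this same place, and it produced no change beyond the scatter. Going by the values given here, it swapped one ring for a different one, however, and no measured step adds a second chlorine to a ring that already carries one, so the data give no direct guide for this change. A step of a 1.1-fold higher number from compound 3 to compound 4 (0.04 log units; within the scatter) is therefore expected, that is, little or no change beyond the scatter. Compound 4 is expected to give about 13000 nM, with a likely range from 4500 nM to 38000 nM.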

Compound 4, half-maximal inhibitory concentration: > 50000 nM
Compound 4 ended at the assay's limit; the forecaster's own chance of this, stated with the estimate: 5%; middle value at least 3.8-fold (0.58 log units) away from the limit.
By their numbers in this assay, from the lowest: compound 3; then compounds 2 and 1 (each within the scatter of the next). At a limit, above all of these: compound 4.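

In this assay, putting 2,4-dichlorophenyl in place of 3-chlorophenyl on a double-bonded chain carbon bound to a double-bonded ring carbon gives an at least 4.2-fold higher number from compound 3 to compound 4 (0.62 log units; beyond the scatter). This shows that the number can respond to the ring at this place, which the earlier exchange, a 1.0-fold lower number from compound 1 to compound 2 (0.01 log units; within the scatter), did not show, and that a small change in the chlorines alone can be enough, with the higher number meaning a weaker inhibitor. Compound 4 gives > 50000 nM, which is a limit of the assay and not a number, so the step has a known minimum but no known full size: the limit of > 50000 nM in this assay, at which 1 of the 4 values shown sits.

The exchange both adds a chlorine and changes the arrangement of the chlorines on the ring, and the compounds shown do not tell which of the two accounts for the step. They also leave open how the number would respond at this place to a ring carrying something other than chlorine or methoxy, such as an amine or a carboxylic acid.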